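The source may hold more compounds than are shown below. What is called first, only, known or untested is meant among the compounds shown, and "the series" means these compounds.

Values measured so far in a functional assay on Jurkat cells (Homo sapiens) for inhibition, read by MTT assay, with a stated time of 72 h; a higher number here means a weaker inhibitor, a lower number a stronger inhibitor
- Compound 1 (`C=C(Br)C(=O)Nc1cccc(/C=C/C(=O)Nc2cccc(F)c2)c1`) gives 1000 nM
- Compound 2 (`C=C(Br)C(=O)Nc1cccc(/C=C/C(=O)Nc2ccc(Cl)cc2)c1`) gives 2600 nM

Of these two, compound 2 holds the higher number and is thus the weaker inhibitor, with compound 1 below it. Compound 3 (`C=C(Br)C(=O)Nc1cccc(/C=C/C(=O)Nc2ccc(OC)cc2)c1`) differs from compound 2 by a single change (methoxy in place of chloro on an aromatic carbon), methoxy in place of chloro on an aromatic carbon, para to a large group. Within the data shown here, the one measured step that bears on this (a 2.6-fold higher number from compound 1 to compound 2 (0.41 log units; beyond the scatter)) also altered the substituted phenyl on the amide-type nitrogen, but no measured step exchanges these two groups. A modest change no larger than that one is therefore expected in this assay, and probably none beyond the scatter, with a slight lean toward a lower number. The estimate amounts to an expected 1.3-fold lower number from compound 2 to compound 3 (0.11 log units; within the scatter). For compound 3 the expected value is 2000 nM, with an estimated range from 700 nM to 5500 nM.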

Compound 3, half-maximal inhibitory concentration: 470 nM
The estimate for compound 3 lay 4.3-fold (0.63 log units) above the measured number; the whole stated range lies above it.
By their numbers in this assay, from the lowest: compound 3; then compound 1; then compound 2.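

In this assay the exchange of chloro for methoxy on the aromatic carbon para to a large group gives a 5.5-fold lower number from compound 2 to compound 3 (0.74 log units; beyond the scatter) and shows that the group at this place can shift the number well towards a stronger inhibitor. The 4-methoxyphenyl group also outdoes the 3-fluorophenyl group, with a 2.1-fold lower number from compound 1 to compound 3 (0.33 log units; beyond the scatter) in this assay and so the weak reading of compound 2 cannot be taken as a penalty for every group at this place. Nothing measured here accounts for the step.

The compounds shown leave open how an amine, a hydroxyl or a longer chain such as ethoxy would read at this same place. They also leave open whether the gain from methoxy would persist if the bromine of the shared core were exchanged for another group.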